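The source may report more compounds than this note shows. Statements on the series, on what has been measured and on what is new or still open speak of the compounds shown alone.

Measured so far:
compound 1, `CS(=O)(=O)Oc1c(C(=O)NCc2ccc(F)cc2)nc(Br)c2cccnc12`, in a functional assay on MDA-MB-435 cells (Homo sapiens) for cytotoxicity, read by MTT assay, with a stated time of 72 h (a higher number here means a weaker inhibitor, a lower number a stronger inhibitor), gives > 20000 nM;
compound 2, `N[C@H]1CC[C@H](Nc2c(C(=O)NCc3ccc(Oc4ccccc4)cc3)nc(Br)c3cccnc23)CC1`, in this assay gives 4000 nM;
compound 3, `O=C(NCc1ccc(F)cc1)c1nc(NCCO)c2cccnc2c1O`, in this assay gives > 20000 nM.

The value given for compound 1 is a limit of this assay and not a number. The value given for compound 3 is likewise a limit. Compound 2 is the only one of the three with a numerical reading. On the numbers shown, compound 1 therefore stands at the limit of > 20000 nM in this assay, at which 2 of the 3 values shown sit, and nothing closer than that can be said of it.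

Compound 4, `COC(=O)CNc1c(C(=O)NCc2ccc(F)cc2)nc(Br)c2cccnc12`, has not yet been measured in this assay. It differs from compound 1 in one place: ((methoxycarbonyl)methyl)amino in place of (methylsulfonyl)oxy on an aromatic carbon. The group that leaves is (methylsulfonyl)oxy; the group that enters is ((methoxycarbonyl)methyl)amino, sitting on an aromatic carbon of a six-membered aromatic ring with one nitrogen, para to a bromo group.

Among the compounds with values here, no step between measured compounds exists to lean on. Compound 3, which also carries an amino-type group at the shared core, gives a reading at the limit, which suggests the change is unlikely to move the reading far. The expected step is an at least 1.3-fold lower number from compound 1 to compound 4 (0.12 log units; that floor lies within the scatter), and is estimated to be small or none beyond the scatter, if anything toward slightly stronger inhibition. Compound 4 is expected to give 15000 nM, with a range from 4000 nM to 40000 nM.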

Compound 4, half-maximal inhibitory concentration: 10000 nM
Estimate against measurement, compound 4: 1.5-fold (0.18 log units) above; the range from low to high includes it.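

The exchange of (methylsulfonyl)oxy for ((methoxycarbonyl)methyl)amino on this aromatic carbon, para to a bromo group, yields a reading that can be stated as a number: in this assay compound 4 gives 10000 nM. From the compounds shown here alone, the starting point, however, is not a number, as the reading for compound 1 is a limit of the assay: the limit of > 20000 nM in this assay, at which 2 of the 4 values shown sit. The step is an at least 2.0-fold lower number from compound 1 to compound 4 (0.30 log units; that floor lies within the scatter), so this one change gives only a floor, and its true size remains unknown.

The compounds shown do not separate the contribution of the amino link from that of the methyl ester, since both arrive together in the entering group. Going by these compounds, a carboxylic acid in place of the methyl ester, or a longer chain between the amino nitrogen and the carbonyl, would address that question on the same core, and it also remains open whether a step beyond the scatter can be reached at this position.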